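Swapping the Aryl Cap on the Alkyne of Compound 3

The compounds below may be only part of what the source reports. "The series", "measured", "known", "first", "only" and "open" are said of these compounds alone.

Of the compounds shown here, three sharing one core have been measured. In an assay on Sf9 cells for inhibition of mitogen-activated protein kinase kinase kinase 14 variant S549D (Homo sapiens), with a stated time of 30 min, in the presence of a further agent that is not named here (a higher number here means a weaker inhibitor, a lower number a stronger inhibitor), compound 1 `C#Cc1ccc2ncn(-c3ccnc(N)n3)c2c1` gives 251 nM. Compound 2 `CC(=O)NCCCCc1ccc2ncn(-c3ccnc(N)n3)c2c1` gives 398000 nM, and compound 3 `C#Cc1cc(C#Cc2ccc3ncn(-c4ccnc(N)n4)c3c2)ccn1` gives 31600 nM, the second highest of the three numbers, a step of a 130-fold higher number from compound 1 to compound 3 (2.10 log units; beyond the scatter) and with compound 2 further off still. Compound 4 `C=Cc1nccc(C#Cc2ccc3ncn(-c4ccnc(N)n4)c3c2)n1` has not yet been measured; it differs from compound 3 by a group of 8 heavy atoms (6 carbon, 2 nitrogen; one six-membered aromatic ring with 2 hetero atoms) in place of a group of 8 heavy atoms (7 carbon, 1 nitrogen; one six-membered aromatic ring with 1 hetero atom), on a triple-bonded carbon, the change sitting on a triple-bonded carbon whose other neighbour is a triple-bonded carbon. For the measured compounds named here, the steps that bear on this place are a 130-fold higher number from compound 1 to compound 3 (2.10 log units; beyond the scatter) and a 1600-fold higher number from compound 1 to compound 2 (3.20 log units; beyond the scatter), both of which enlarge the substituent; here the size is unchanged and only the ring and its appendage differ, so no step beyond the scatter is expected in this assay , in either direction, and the expected step is a 1.1-fold lower number from compound 3 to compound 4 (0.02 log units; within the scatter). Compound 4 is therefore estimated at 30000 nM, with a range from 8000 nM to 120000 nM.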

Compound 4, half-maximal inhibitory concentration: 39800 nM
Estimate against measurement, compound 4: 1.3-fold (0.12 log units) below; the range from low to high includes it.
By their numbers in this assay, from the lowest: compound 1; then compounds 3 and 4 (each within the scatter of the next); then compound 2.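

In this assay, the step of a 1.3-fold higher number from compound 3 to compound 4 (0.10 log units; within the scatter) shows that two caps of equal size, differing in ring nitrogen count and in a triple or double bond outside the ring, read alike at this triple-bonded carbon. The step of a 160-fold higher number from compound 1 to compound 4 (2.20 log units; beyond the scatter) shows that the large gap seen for compound 3 recurs with a second capped compound, so it is not confined to one particular cap. Nothing at hand accounts for either step.

Because the ring and its appendage change together, compounds 3 and 4 cannot show whether each change alone is without consequence or whether the two offset each other. On these data alone, what a plain phenyl ring, or a ring carrying an amine or a carboxylic acid, would give on this carbon also remains open.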